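Ethyl for cyclopropyl on the amino nitrogen of compound 1

A few compounds are considered here, and "the series" means these few. Any claim that something is new, unique, unknown or untested is made for them only; others in the source may bear on it.

Compound 1 `CCn1c(NC2CC2)nc2ccsc2c1=O` gives 2600 nM in an assay on cells for inhibition of high affinity 3',5'-cyclic-AMP phosphodiesterase 7A (Homo sapiens), read by scintillation counting and cAMP accumulation, with a stated time of 30 min (on this read-out lower numbers stand for stronger inhibition and higher numbers for weaker inhibition), the highest of the three numbers recorded. Its nearest neighbour is compound 3 `CCn1c(N[C@H]2CC[C@H](C(=O)OC)CC2)nc2ccsc2c1=O`, which gives 2100 nM in this assay; the two values lie within the scatter of each other, so no order between them can be stated. Far apart from both stands compound 2 `CCn1c(NC(C)C)nc2c(C3CCN(C(=O)c4ccccc4)C3)csc2c1=O`, which gives 1.5 nM in this assay, a gap that lies well beyond the scatter. Compound 2 differs from compound 1 in more than one place, so what drives that gap cannot be read from these three compounds alone.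

Compound 4 `CCNc1nc2ccsc2c(=O)n1CC` has not yet been measured. It differs from compound 1 by ethyl in place of cyclopropyl on a nitrogen on an aromatic ring. Going by the values given here, no measured pair isolates this change, so the size of the step is an open question. For compound 4 the step of a 1.2-fold higher number from compound 1 to compound 4 (0.06 log units; within the scatter) is expected to stay within the scatter in this assay. Compound 4 is accordingly estimated at 3000 nM, with a range from 1200 nM to 8000 nM.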

Compound 4, half-maximal inhibitory concentration: 2900 nM
Beside the measured number, compound 4's estimate is 1.0-fold (0.01 log units) above it; measured number inside the range.
By their numbers in this assay, from the lowest: compound 2; then compounds 3, 1 and 4 (each within the scatter of the next).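

The exchange of cyclopropyl for ethyl on a nitrogen on an aromatic ring now has a measured size: in this assay the step is a 1.1-fold higher number from compound 1 to compound 4 (0.05 log units; within the scatter). On the core of compound 1, then, this position tolerates the loss of the three-membered ring without a difference that can be stated, so the ring itself is not needed to hold the number at this level. No measurement shown offers an explanation for this result.

On these data alone, whether a longer chain such as butyl, or a carboxylic acid carried on this nitrogen, would read differently remains open. As far as these compounds go, it is equally open whether ethyl and cyclopropyl would still read alike on the core of compound 2, where the numbers are far lower.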